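Swapping an Aryl Amide for a Benzyl Amide

A few compounds are considered here, and "the series" means these few. Any claim that something is new, unique, unknown or untested is made for them only; others in the source may bear on it.

Compound 2 `C=CC1=C(C(=O)Nc2ccccc2OC)C(c2ccc(F)cc2)OC1` carries a 2-methoxyphenyl on its amide nitrogen. In a functional assay on SW480 cells (Homo sapiens) for cytotoxicity, read by MTT assay, with a stated time of 24 h (on this read-out higher numbers stand for weaker inhibition and lower numbers for stronger inhibition), compound 2 reaches only the limit of the measurement, > 100000 nM. Compound 1 `C=CC1=C(C(=O)NCCC)C(c2ccc(F)cc2)OC1`, with propyl in that place, gives > 100000 nM, likewise a limit. The step that the two limits leave unreadable from compound 1 to compound 2 therefore cannot be sized. Compound 3 `C=CC1=C(C(=O)NCc2ccccc2F)C(c2ccc(F)cc2)OC1` differs from compound 2 by 2-fluorobenzyl in place of 2-methoxyphenyl on an amide-type nitrogen. For the measured compounds named here, the only measured step at this position is unreadable, and the limit of > 100000 nM in this assay, at which 2 of the 2 values shown sit, shows both known values sitting at the limit. Compound 3 is expected to behave similarly, with an estimated step of a number no higher from compound 2 to compound 3 (the limit leaves the size open). Compound 3 is thus estimated at 100000 nM, between 30000 nM and 300000 nM.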

Compound 3, half-maximal inhibitory concentration: > 100000 nM
Compound 3 was reported as a limit (the forecaster's own chance of this, stated with the estimate: 75%); the middle value sits exactly at the limit.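

Compound 1, compound 2 and compound 3 all stop at a limit, so no step among them can be read: the limit of > 100000 nM in this assay, at which 3 of the 3 values shown sit.

The compounds shown leave open whether any group on the amide nitrogen of the shared core gives a measurable value in this assay.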